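This account rests on a few compounds, and the source may have more. Where it says the series, first, only, none or still open, it means among the compounds named here.

Working notes on the series. In an ADME assay on blood (Homo sapiens) for pharmacokinetics (a lower number here means that the compound disappears faster, a higher number that the compound lasts longer), compound 1 `COC(=O)CCNC(=O)[C@@H]1O[P@@](=O)(OCOC(=O)c2ccnn2C)OCC1(C)C` stands at a limit of the assay, > 1 h. Compound 2 `COC(=O)CCNC(=O)[C@@H]1O[P@](=O)(OCOC(=O)c2scnc2C)OCC1(C)C` stands at the opposite limit, < 0.16 h. Compound 3 `CC(C)(C)C(=O)OCO[P@@]1(=O)OCC(C)(C)[C@H](C(=O)NCCC(=O)O)O1` also sits at a limit, > 1 h. Two of the three values shown rest at the limit of > 1 h in this assay, at which 2 of the 3 values shown sit, and one at the limit of < 0.16 h in this assay, at which 1 of the 3 values shown sits, so no numbered step exists between the measured compounds. Compound 4 `CC(C)(C)C(=O)OCO[P@@]1(=O)OCC(C)(C)[C@H](C(=O)NCCC(=O)OCc2cncs2)O1` differs from compound 3 by (1,3-thiazol-5-yl)methyl in place of hydrogen on an oxygen next to a carbonyl group. Within the data shown here, no measured pair matches this change. The step of an at least 2.0-fold lower number from compound 3 to compound 4 (0.30 log units; that floor lies within the scatter) is expected to run downward, beyond the scatter, although the limit for compound 3 leaves its size open. Compound 4 is estimated at 0.5 h, with a range from 0.15 h to 1.5 h.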

Compound 4, half-life: < 0.16 h
Compound 4: no number, only a limit; the forecaster's own chance of this, stated with the estimate: 40%; middle value at least 3.1-fold (0.49 log units) away from the limit.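

In this assay, among these compounds, the oxygen next to a carbonyl group now carries the first readable step: (1,3-thiazol-5-yl)methyl in place of hydrogen gives an at least 6.2-fold lower number from compound 3 to compound 4 (0.79 log units; beyond the scatter). Compound 3 rests at a limit, > 1 h. Compound 4 rests at the opposite limit, < 0.16 h, so the step fixes a direction and only a floor for its size.

The compounds shown leave open whether the step belongs to the thiazole ring or to the ester as such. A benzyl or ethyl ester on the same oxygen would separate the two.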